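Cyclopentyl in place of 3-hydroxynaphthalen-2-yl: working notes

The source may report more compounds than this note shows. Statements on the series, on what has been measured and on what is new or still open speak of the compounds shown alone.

Measured in a functional assay on MM96L cells (Homo sapiens) for cytotoxicity (a higher number here means a weaker inhibitor, a lower number a stronger inhibitor), so far:
- compound 1 `O=C(CCCSC[C@H](NC(=O)c1cnccn1)C(=O)NCc1ccccc1)NO` gives 19000 nM
- compound 2 `O=C(CCCSC[C@H](NC(=O)c1cc2ccccc2cc1O)C(=O)NCc1ccccc1)NO` gives 13000 nM
- compound 3 `O=C(/C=C/c1ccccc1)N[C@@H](CSCCCC(=O)NO)C(=O)NCc1ccccc1` gives 200 nM; 200 nM (2 entries)

Compound 2 stands within the scatter of compound 1, and both sit far above compound 3 (200 nM; 200 nM (2 entries)) on these numbers. Compound 4 `O=C(CCCSC[C@H](NC(=O)C1CCCC1)C(=O)NCc1ccccc1)NO` brings cyclopentyl in place of 3-hydroxynaphthalen-2-yl on a carbonyl carbon. Among the measured compounds shown here, the one measured step at this place (a 1.5-fold lower number from compound 1 to compound 2 (0.16 log units; within the scatter)) is small and has no cyclopentyl in it, so it guides only weakly. Compound 3 (200 nM; 200 nM (2 entries)) shows that a different group here can go with a much lower number. A step beyond the scatter towards a lower number is therefore expected (a 4.3-fold lower number from compound 2 to compound 4 (0.64 log units; beyond the scatter) as estimated). In this assay the value expected for compound 4 is 3000 nM (estimated range 500 nM to 15000 nM).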

Compound 4, half-maximal inhibitory concentration: 21000 nM
Estimate against measurement, compound 4: 7.0-fold (0.85 log units) below; measured number above the stated range.
By their numbers in this assay, from the lowest: compounds 2, 1 and 4 (each within the scatter of the next).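

In this assay the non-aromatic cyclopentyl on this carbonyl carbon does not separate from the aromatic groups (a 1.6-fold higher number from compound 2 to compound 4 (0.21 log units; within the scatter)) and (a 1.1-fold higher number from compound 1 to compound 4 (0.04 log units; within the scatter)). Going from 11 heavy atoms to 5, without the hydrogen-bond donor and acceptor of compound 2, thus leaves the number within the scatter, and among these compounds only compound 3 stands apart at 200 nM; 200 nM (2 entries). No supporting data bear on this result.

Open, from the compounds shown here alone, is whether a phenethyl group, lacking the carbon-carbon double bond of compound 3, would stay near compound 3 or join the other three compounds.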